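Shifting the Pyrazole Attachment Point from Compound 2 to Compound 3

This account rests on a few compounds, and the source may have more. Where it says the series, first, only, none or still open, it means among the compounds named here.

Measured so far:
- compound 1, `CNC(=O)N1CCCc2ccc(NC(=O)c3cccc(-c4ccccc4)c3)cc21`: in a functional assay on MV4-11 cells (Homo sapiens) for antiproliferative activity, with a stated time of 6 days, tested at 6.25 uM (a lower number here means a weaker effect, a higher number a stronger effect of the compound at the concentration tested), compound 1 gives 1.39%
- compound 2, `CNC(=O)N1CCCc2ccc(NC(=O)c3ccc(-c4cnn(S(C)(=O)=O)c4)cc3)cc21`: in this assay compound 2 gives 40.2%

Among the two numbers shown, compound 2 stands highest. Its nearest neighbour is compound 1, whose value lies far below it, a gap well beyond the usual scatter of this measurement.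

Compound 3, `CNC(=O)N1CCCc2ccc(NC(=O)c3ccc(-c4ccn(S(C)(=O)=O)n4)cc3)cc21`, has not yet been measured. It differs from compound 2 in a single place: 1-(methylsulfonyl)-1H-pyrazol-3-yl in place of 1-(methylsulfonyl)-1H-pyrazol-4-yl on an aromatic carbon. The two groups are built from the same atoms, joined differently, so the change is small in size; only the point at which the five-membered ring attaches to the aromatic carbon moves.

Within the data shown here, no step between two measured compounds of this kind is available, so the direction of the change cannot be read from the data. Given how little the structure shifts, I expect a modest downward step, a number 10.2 percentage points lower from compound 2 to compound 3 (beyond the scatter), possibly none beyond the scatter. For compound 3 the estimated value is 30%, with a range from 10% to 52%.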

Compound 3, a percentage reported as inhibition, at one concentration (the size of the read-out at that concentration, not a potency): 57.2%
For compound 3 the middle estimate is 27.2 percentage points below the measured one; measured number outside the range, above it.
By their numbers in this assay, from the lowest: compound 1; then compound 2; then compound 3.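

In this assay, putting 1-(methylsulfonyl)-1H-pyrazol-3-yl in place of 1-(methylsulfonyl)-1H-pyrazol-4-yl gives a number 17 percentage points higher from compound 2 to compound 3 (beyond the scatter). Among these compounds, this is the first comparison here between two compounds that differ in one place, and it shows that on this aromatic carbon, para to a large group, the read-out responds to the point at which the five-membered ring attaches, even though the two groups are built from the same atoms and have the same counts of hydrogen-bond donors and acceptors. The data offer no measurement that could explain the step.

On these data alone, whether the same step would appear with another group in place of the methylsulfonyl, such as an acetyl or a plain methyl, stays open. As far as these compounds go, the read-out also comes from a single concentration and gives the size of the effect there rather than a potency, so how far the two compounds differ in potency remains unknown.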